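The compounds below may be only part of what the source reports. "The series", "measured", "known", "first", "only" and "open" are said of these compounds alone.

Measured in an assay on isolated protein for inhibition of Amine oxidase [flavin-containing] B (Homo sapiens), read by fluorescence, with stated times of 15 min and 20 min; on this read-out lower numbers stand for stronger inhibition and higher numbers for weaker inhibition:
compound 1 `CC(C)(C)c1cc(/C=C/C(=O)NCCC2CCN(Cc3ccccc3)CC2)cc(C(C)(C)C)c1O` gives 8500 nM;
compound 2 `Cc1ccccc1CN1CCC(CCNC(=O)/C=C/c2cc(C(C)(C)C)c(O)c(C(C)(C)C)c2)CC1` gives 7200 nM;
compound 3 `CC(C)(C)c1cc(/C=C/C(=O)NCCC2CCN(Cc3cccc(F)c3)CC2)cc(C(C)(C)C)c1O` gives 6500 nM.

Compound 2 sits amid the other two: the step of a 1.2-fold lower number from compound 1 to compound 2 (0.07 log units; within the scatter) and the step of a 1.1-fold lower number from compound 2 to compound 3 (0.04 log units; within the scatter) both leave the three numbers indistinguishable. Compound 4 `CC(C)(C)c1cc(/C=C/C(=O)NCCC2CCN(Cc3ccc(Br)cc3)CC2)cc(C(C)(C)C)c1O` differs from compound 2 in one place: 4-bromophenyl in place of 2-methylphenyl on a saturated chain carbon bound to an amine nitrogen in a ring. Within the data shown here, the steps that bear on this change all alter the phenyl group on the saturated chain carbon bound to the amine nitrogen in the ring; besides the two named, a 1.3-fold lower number from compound 1 to compound 3 (0.12 log units; within the scatter) also stays within the scatter. Nothing seen so far suggests a substituent change on that phenyl shifts the number beyond the scatter. Because a 1.1-fold lower number from compound 2 to compound 3 (0.04 log units; within the scatter) stayed within the scatter, compound 4 is expected to show a step of a 1.1-fold lower number from compound 2 to compound 4 (0.04 log units; within the scatter). The estimate for compound 4 in this assay is 6500 nM, ranging from 3000 nM to 14000 nM.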

Compound 4, half-maximal inhibitory concentration: 13200 nM
Compound 4: the middle estimate sits 2.0-fold (0.31 log units) below what was measured; low and high end bracket the measured number.
By their numbers in this assay, from the lowest: compounds 3, 2, 1 and 4 (each within the scatter of the next, the first and the last beyond it).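

On a saturated chain carbon bound to an amine nitrogen in a ring, exchanging the substituted phenyl group can move the number in this assay beyond the scatter, though only modestly: 4-bromophenyl in place of 3-fluorophenyl gives a step (a 2.0-fold higher number from compound 3 to compound 4 (0.31 log units; beyond the scatter)) that passes it. The other two steps (a 1.8-fold higher number from compound 2 to compound 4 (0.26 log units; within the scatter)) and (a 1.6-fold higher number from compound 1 to compound 4 (0.19 log units; within the scatter)) stay within the scatter, so this single pair carries the shift. No evidence here explains that shift.

From the compounds shown here alone, it remains open how a phenyl group carrying an amine or a carboxylic acid would read at this position, and whether 2-bromophenyl or 3-bromophenyl would match 4-bromophenyl.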